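Swapping piperidin-4-yl for pyridin-4-yl in compound 1

The compounds below may be only part of what the source reports. "The series", "measured", "known", "first", "only" and "open" are said of these compounds alone.

For the measured compounds named here, in a functional assay on A2780 cells (Homo sapiens) for antiproliferative activity, read by fluorescence, with a stated time of 72 h (on this read-out lower numbers stand for stronger inhibition and higher numbers for weaker inhibition), compound 1 (`CC(C)(C)C(=O)N1Cc2c(NC(=O)C3CCNCC3)n[nH]c2C1(C)C`) gives 650 nM and so holds the higher of the two numbers known so far. Compound 2 (`CN1CCC(C(=O)N2Cc3c(NC(=O)c4ccc(Cl)cc4)n[nH]c3C2(C)C)CC1`) gives 120 nM and the gap between the two lies beyond the usual scatter. Compound 3 (`CC(C)(C)C(=O)N1Cc2c(NC(=O)c3ccncc3)n[nH]c2C1(C)C`) has not been measured yet. It keeps the core of compound 1 and carries pyridin-4-yl in place of piperidin-4-yl on a carbonyl carbon. The new six-membered ring is aromatic, while the old one was not. Going by the values given here, no measured pair shows this change alone, so any forecast is loose. Among the compounds with values here, compound 2 at 120 nM shows only that a number lower than that of compound 1 is reachable on the shared core. A small expected step toward a lower number (a 1.6-fold lower number from compound 1 to compound 3 (0.21 log units; within the scatter)) would probably stay within the scatter. The expected value for compound 3 is 400 nM and the estimated range runs from 130 nM to 1300 nM on this reasoning.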

Compound 3, half-maximal inhibitory concentration: 110 nM
Estimate against measurement, compound 3: 3.6-fold (0.56 log units) above, outside the stated range (below it).
By their numbers in this assay, from the lowest: compounds 3 and 2 (each within the scatter of the next); then compound 1.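

At this carbonyl carbon, the nature of the ring clearly matters in this assay: pyridin-4-yl in place of piperidin-4-yl gives a 5.9-fold lower number from compound 1 to compound 3 (0.77 log units; beyond the scatter), whereas compound 2 differs from compound 1 in more than one place and could not isolate this change. The two groups have the same heavy atoms, so the step goes with an aromatic ring replacing a non-aromatic one and with the loss of the hydrogen-bond donor, and these two differences cannot be separated here. No measurement offered here accounts for the step.

On these data alone, whether the ring nitrogen of pyridin-4-yl matters remains open, and phenyl at the same carbonyl carbon would address this. Cyclohexyl there would likewise show how a non-aromatic ring without that nitrogen compares.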